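Trimming the group on a potent inhibitor

The source may hold more compounds than are shown below. What is called first, only, known or untested is meant among the compounds shown, and "the series" means these compounds.

Of the compounds shown here, three sharing one core have been tested in a functional assay for inhibition, with Homo sapiens as the target; a higher number here means a weaker inhibitor, a lower number a stronger inhibitor. Compound 1 `CCCC(Oc1ccc2c(c1)c(SC(C)(C)C)c(CC(C)(C)C(=O)O)n2Cc1ccc(Cl)cc1)c1ccc2ccccc2n1` gives only a limit, > 52 nM. Compound 2 `CC(C)(C)Sc1c(CC(C)(C)C(=O)O)n(Cc2ccc(Cl)cc2)c2ccc(OCc3ccc4cccnc4n3)cc12` reads 6 nM, the lowest of the actual numbers, while compound 3 `CC(C)(C)Sc1c(CC(C)(C)C(=O)O)n(Cc2ccc(Cl)cc2)c2ccc(OCc3nc4cc(C(F)(F)F)ccc4s3)cc12` reads 22 nM, a gap beyond the usual scatter.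

Compound 4 `CC(C)(C)Sc1c(CC(C)(C)C(=O)O)n(Cc2ccc(Cl)cc2)c2ccc(OCc3ccncc3)cc12` has not yet been measured. It differs from compound 2 in one place, on a saturated chain carbon bound to an oxygen on an aromatic ring: a group of 6 heavy atoms (5 carbon, 1 nitrogen; one six-membered aromatic ring with 1 hetero atom) in place of a group of 10 heavy atoms (8 carbon, 2 nitrogen; 2 six-membered aromatic rings with 1 hetero atom each), on a saturated chain carbon bound to an oxygen on an aromatic ring. The new group is pyridin-4-yl. Among the compounds with values here, no measured pair isolates this change, and the expectation remains tentative. A move toward a weaker inhibitor, beyond the scatter, is expected: a 6.7-fold higher number from compound 2 to compound 4 (0.82 log units; beyond the scatter). For compound 4 the estimated value is 40 nM, with an expected range from 10 nM to 200 nM.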

Compound 4, half-maximal inhibitory concentration: 6 nM
Compound 4: the middle estimate sits 6.7-fold (0.82 log units) above what was measured; the measured number lies below the stated range.
By their numbers in this assay, from the lowest: compounds 2 and 4 (each within the scatter of the next); then compound 3. At a limit, above all of these: compound 1.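

In this assay there is no change at the digits printed from compound 2 to compound 4 (within the scatter) when pyridin-4-yl replaces the group of 10 heavy atoms on a saturated chain carbon bound to an oxygen on an aromatic ring. At this position, then, one six-membered aromatic ring gives a number matching that of two such rings, so the second ring is not required to reach this level. Nothing measured here accounts for this result.

As far as these compounds go, whether the ring nitrogen of pyridin-4-yl is needed stays open. So does how a phenyl group, with only carbon in its ring, would read on this carbon.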